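Urea terminus of the shared core: cyclopropyl to methyl

The compounds below may be only part of what the source reports. "The series", "measured", "known", "first", "only" and "open" are said of these compounds alone.

Measured compounds in a functional assay on U-87MG ATCC cells for cytotoxicity against U-87 MG (Homo sapiens), read by MTT assay, with a stated time of 72 h; on this read-out lower numbers stand for stronger inhibition and higher numbers for weaker inhibition:
compound 1 `COc1ncc(-c2ccc3nc(NC(=O)NC4CC4)nn3c2)cc1NS(=O)(=O)c1ccc(F)cc1` gives 540 nM
compound 2 `COc1ncc(-c2ccc3nc(NC(=O)NCC(=O)N4CCCC4)nn3c2)cc1NS(=O)(=O)c1ccc(F)cc1` gives 1000 nM
compound 3 `COc1ncc(-c2ccc3nc(NC(=O)NCC(=O)N4CCOCC4)nn3c2)cc1NS(=O)(=O)c1ccc(F)cc1` gives 3260 nM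

Compound 1 has the lowest number of the three; the step of a 1.9-fold higher number from compound 1 to compound 2 (0.27 log units; within the scatter) is within the scatter, whereas a 6.0-fold higher number from compound 1 to compound 3 (0.78 log units; beyond the scatter) and a 3.3-fold higher number from compound 2 to compound 3 (0.51 log units; beyond the scatter) lie beyond it. Compound 4 `CNC(=O)Nc1nc2ccc(-c3cnc(OC)c(NS(=O)(=O)c4ccc(F)cc4)c3)cn2n1` differs from compound 1 by methyl in place of cyclopropyl on an amide-type nitrogen. Among the compounds with values here, no measured step replaces cyclopropyl with a group of fewer heavy atoms, so the measured steps bear only loosely on it: both enlargements of the group on the amide-type nitrogen gave higher numbers, one within and one beyond the scatter. For a smaller group, no step beyond the scatter is expected in this assay. The expected number for compound 4 is 700 nM, with a range of 300 nM to 1600 nM, corresponding to a 1.3-fold higher number from compound 1 to compound 4 (0.11 log units; within the scatter).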

Compound 4, half-maximal inhibitory concentration: 640 nM
Beside the measured number, compound 4's estimate is 1.1-fold (0.04 log units) above it; low and high end bracket the measured number.
By their numbers in this assay, from the lowest: compounds 1, 4 and 2 (each within the scatter of the next); then compound 3.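

In this assay, going from cyclopropyl to methyl on the amide-type nitrogen costs nothing beyond the scatter (a 1.2-fold higher number from compound 1 to compound 4 (0.07 log units; within the scatter)), so the ring of cyclopropyl is not required at this position for a number in this range. Methyl also stays within the scatter of the ((pyrrolidin-1-yl)carbonyl)methyl group (a 1.6-fold lower number from compound 2 to compound 4 (0.19 log units; within the scatter)), while the ((morpholin-4-yl)carbonyl)methyl group remains clearly apart (a 5.1-fold lower number from compound 3 to compound 4 (0.71 log units; beyond the scatter)), making compound 3 the only outlier among the four. Nothing available here explains these differences.

Still open, from the compounds shown here alone, is how a plain ethyl or longer alkyl chain would read at this nitrogen. Also open, going by these compounds, is how a chain ending in a free amine or a carboxylic acid would read.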